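Moving the Imidazole Attachment Point on a Salicylic Acid Core

A few compounds are considered here, and "the series" means these few. Any claim that something is new, unique, unknown or untested is made for them only; others in the source may bear on it.

Measured so far:
- compound 1, `O=C(O)c1cc(-n2ccnc2)ccc1O`: 2000 ug/mL
- compound 2, `O=C(O)c1cc(-c2ncccn2)ccc1O`: 6000 ug/mL

In a physicochemical assay for solubility, in phosphate buffer, at pH 7 (a higher number here means a more soluble compound, a lower number a less soluble compound), compound 1 has the lowest of the two numbers; compound 2 gives a higher number. Its nearest neighbor is compound 2, and that gap lies beyond the scatter. Compound 3, `O=C(O)c1cc(-c2c[nH]cn2)ccc1O`, is not yet measured. It differs from compound 1 in one place: 1H-imidazol-4-yl in place of 1H-imidazol-1-yl on an aromatic carbon. Within the data shown here, with no step between measured compounds to draw on, the step of a 1.3-fold higher number from compound 1 to compound 3 (0.10 log units; within the scatter) is expected to be small, none beyond the scatter. Compound 3 is therefore estimated at 2500 ug/mL, with a range from 1000 ug/mL to 6000 ug/mL.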

Compound 3, solubility: 1100 ug/mL
Compound 3: the middle estimate sits 2.3-fold (0.36 log units) above what was measured; low and high end bracket the measured number.
By their numbers in this assay, from the lowest: compounds 3 and 1 (each within the scatter of the next); then compound 2.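

At the aromatic carbon para to a hydroxy group, this assay now has a step to read: 1H-imidazol-4-yl in place of 1H-imidazol-1-yl gives (a 1.8-fold lower number from compound 1 to compound 3 (0.26 log units; within the scatter)). The two groups hold the same atoms, joined differently, and the entering group carries a hydrogen-bond donor, yet the step stays within the scatter. Nothing available explains this result. Going by these compounds, what stays open is whether a simple amine or a second carboxylic acid at this position would give a step beyond the scatter.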